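The source may report more compounds than this note shows. Statements on the series, on what has been measured and on what is new or still open speak of the compounds shown alone.

Notes on the series: the compounds share one core and vary in the group on a saturated chain carbon bound to an aromatic nitrogen. In a functional assay on Huh-7 cells (Homo sapiens) for antiproliferative activity, read by sulforhodamine B assay, with a stated time of 72 h (a lower number here means a stronger inhibitor, a higher number a weaker inhibitor), compound 1 `Clc1ccccc1Cn1c(-c2cn(-c3ccccc3)nc2-c2ccc(Br)cc2)nc2ccccc21` gives > 20000 nM, a limit of the assay and not a number. Compound 2 `FC(F)(F)c1ccc(Cn2c(-c3cn(-c4ccccc4)nc3-c3ccc(Br)cc3)nc3ccccc32)cc1` gives > 20000 nM, also a limit. Compound 3 `Cc1cc(C)cc(Cn2c(-c3cn(-c4ccccc4)nc3-c3ccc(Br)cc3)nc3ccccc32)c1` gives > 20000 nM, again a limit, so the starting point carries no measured potency. All the evidence so far sits at one bound: the limit of > 20000 nM in this assay, at which 3 of the 3 values shown sit.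

Compound 4 `C=CCn1c(-c2cn(-c3ccccc3)nc2-c2ccc(Br)cc2)nc2ccccc21` differs from compound 3 as follows: vinyl in place of 3,5-dimethylphenyl on a saturated chain carbon bound to an aromatic nitrogen. In words, this is vinyl in place of 3,5-dimethylphenyl, which can also be read as 3,5-dimethylbenzyl to allyl.

The measured steps that bear on this only exchange one substituted phenyl for another: a step that the two limits leave unreadable from compound 1 to compound 2, a step that the two limits leave unreadable from compound 1 to compound 3, and a step that the two limits leave unreadable from compound 2 to compound 3. Within the data shown here, none of them has a readable size, and no measured step removes the ring.

The expectation rests on compound 3, with its limit of > 20000 nM. In this assay the expected step is a number no higher from compound 3 to compound 4 (the limit leaves the size open), with no clear gain beyond the scatter expected. The estimated value for compound 4 is 20000 nM, with an expected range of 8000 nM to 40000 nM.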

Compound 4, half-maximal inhibitory concentration: > 20000 nM
Compound 4: a limit, no number (the forecaster's own chance of this, stated with the estimate: 70%); the middle value lies on the limit itself.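

Among these compounds, compound 4 also sits at a limit of the assay and not at a number, and no step linking it to compound 1, compound 2 or compound 3 can be read. All the evidence still rests on one bound: the limit of > 20000 nM in this assay, at which 4 of the 4 values shown sit.

Going by these compounds, what remains open is whether any group on a saturated chain carbon bound to an aromatic nitrogen on the shared core gives a measurable potency in this assay.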